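Swapping a Cyano for Phenyl on the Amide Side Chain

The source may report more compounds than this note shows. Statements on the series, on what has been measured and on what is new or still open speak of the compounds shown alone.

Measured compounds in a functional assay on HEK293 cells for agonist activity at lutropin-choriogonadotropic hormone receptor (Homo sapiens), read by cAMP accumulation; a lower number here means a smaller maximal response, a higher number a larger maximal response:
- Compound 1 `COc1cccc(-c2nc(SC)nc3sc(C(=O)NCC#N)c(N)c23)c1` gives 20.3%.
- Compound 2 `COc1cccc(-c2nc(SC)nc3sc(C(=O)OC(C)(C)C)c(N)c23)c1` gives 23.8%.
- Compound 3 `COc1cccc(-c2nc(SC)nc3sc(C(=O)N(C)C)c(N)c23)c1` gives 11%.

Compound 1 stands second highest of the three; compound 2 lies a number 3.5 percentage points higher from compound 1 to compound 2 (within the scatter) and compound 3 lies a number 9.3 percentage points lower from compound 1 to compound 3 (within the scatter), both within the scatter. Compound 4 `COc1cccc(-c2nc(SC)nc3sc(C(=O)NCc4ccccc4)c(N)c23)c1` differs from compound 1 by phenyl in place of cyano on a saturated chain carbon bound to an amide-type nitrogen. Among the measured compounds shown here, the steps that bear on this are those that exchanged the group on the carbonyl carbon: compound 1 to compound 2 and to compound 3 stayed within the scatter, and only a number 12.8 percentage points lower from compound 2 to compound 3 (beyond the scatter) was modest. A step of no size beyond the scatter is therefore expected, a number 0.3 percentage points lower from compound 1 to compound 4 (within the scatter). Compound 4 is estimated at 20%, between 8% and 32%.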

Compound 4, largest response reached (reported as efficacy), in percent of the reference or control that the assay uses: 7.8%
Compound 4: the middle estimate sits 12.2 percentage points above what was measured; the measured number lies below the stated range.
By their numbers in this assay, from the lowest: compounds 4, 3, 1 and 2 (each within the scatter of the next, the first and the last beyond it).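

In this assay, the group on the saturated chain carbon bound to an amide-type nitrogen does count: phenyl in place of cyano gives a step beyond the scatter (a number 12.5 percentage points lower from compound 1 to compound 4 (beyond the scatter)), which neither earlier exchange from compound 1 did. Benzylamino on the carbonyl carbon cannot be told apart from dimethylamino (a number 3.2 percentage points lower from compound 3 to compound 4 (within the scatter)), yet it falls clearly short of tert-butoxy (a number 16 percentage points lower from compound 2 to compound 4 (beyond the scatter)). Nothing available here accounts for the drop.

From the compounds shown here alone, whether it belongs to the aromatic ring or simply to the extra atoms stays open. Cyclohexyl or a longer chain such as phenethyl in this place would help separate the two.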